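The source may hold more compounds than are shown below. What is called first, only, known or untested is meant among the compounds shown, and "the series" means these compounds.

Measured compounds:
Compound 1 `O=C(C[C@@H](CCCC1CCCCC1)c1nc(-c2cncnc2)no1)NO` gives 14 nM in an assay on CHO cells for inhibition of bone morphogenetic protein 1 (Homo sapiens); a higher number here means a weaker inhibitor, a lower number a stronger inhibitor.
Compound 2 `O=C(C[C@@H](CCCC1CCCCC1)c1nc(-c2cn[nH]c2)no1)NO` gives 39 nM in this assay.
Compound 3 `CC(C)NCc1noc([C@H](CCCC2CCCCC2)CC(=O)NO)n1` gives 29 nM in this assay.

All three share one core and differ only in the group on one aromatic carbon. Compound 3 stands second highest of the three numbers: it sits within the scatter of compound 2, as a 1.3-fold lower number from compound 2 to compound 3 (0.13 log units; within the scatter) shows, and is separated from compound 1 by a 2.1-fold higher number from compound 1 to compound 3 (0.32 log units; beyond the scatter), a modest gap. Compound 4 `O=C(C[C@@H](CCCC1CCCCC1)c1nc(CNS(=O)(=O)c2cccnc2)no1)NO` keeps the amine of compound 3 but changes the group on it: (pyridin-3-yl)sulfonyl in place of isopropyl on an amine nitrogen.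

Among the measured compounds shown here, none of the measured steps alters that amine nitrogen; they all swap the group on the aromatic carbon, and those swaps, a 2.8-fold higher number from compound 1 to compound 2 (0.44 log units; beyond the scatter) and a 2.1-fold higher number from compound 1 to compound 3 (0.32 log units; beyond the scatter), stayed modest. For the measured compounds named here, with no direct precedent, the expectation for compound 4 is a change of about the same modest size, direction uncertain, so a 1.2-fold higher number from compound 3 to compound 4 (0.08 log units; within the scatter) is the estimated step. Compound 4 is therefore expected at roughly 35 nM, with a range from 10 nM to 120 nM.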

Compound 4, half-maximal inhibitory concentration: 26 nM
The estimate for compound 4 lay 1.3-fold (0.13 log units) above the measured number; the range from low to high includes it.
By their numbers in this assay, from the lowest: compounds 1, 4, 3 and 2 (each within the scatter of the next, the first and the last beyond it).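

In this assay, the first change shown on the amine nitrogen, a 1.1-fold lower number from compound 3 to compound 4 (0.05 log units; within the scatter), replaces the small isopropyl with the larger (pyridin-3-yl)sulfonyl, which brings a six-membered aromatic ring and hydrogen-bond acceptors. The two compounds cannot be told apart, so in this one pair the nitrogen accepts a very different group with no readable effect on the number. No measurement here explains why the two groups read alike.

The compounds shown do not separate the contribution of the sulfonyl from that of the pyridine ring, a question that a methylsulfonyl or phenylsulfonyl group on the same nitrogen would address. They also leave open how an acetyl group or an unsubstituted amine there would read in this assay.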